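This account rests on a few compounds, and the source may have more. Where it says the series, first, only, none or still open, it means among the compounds named here.

Compound 2 `CN1CCC(C(=O)NCCCNc2nc(Nc3cccc(F)c3)ncc2Br)CC1` is the weakest of the three measured compounds in an assay on isolated protein for inhibition of serine/threonine-protein kinase TBK1 (Homo sapiens) (a lower number here means a stronger inhibitor, a higher number a weaker inhibitor), where compound 2 gives 4300 nM. The two others share a cyclobutylcarbonyl amide on a three-carbon chain and a cyclopropyl group on the core: compound 1 `CC(C)n1cc(Nc2ncc(C3CC3)c(NCCCNC(=O)C3CCC3)n2)cn1` gives 4 nM, and compound 3 `CN(C)Cc1ccc(Nc2ncc(C3CC3)c(NCCCNC(=O)C3CCC3)n2)cc1` gives 6 nM. Between those two, the change of the aromatic group on the ring nitrogen gave a 1.5-fold higher number from compound 1 to compound 3 (0.18 log units; within the scatter), so the two numbers are not distinguishable.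

Compound 4 `O=C(NCCCNc1nc(Nc2cccc(F)c2)ncc1Br)C1CCC1` keeps the bromine-bearing core and the fluorophenyl group of compound 2 and changes only the amide end: cyclobutyl in place of 1-methylpiperidin-4-yl on a carbonyl carbon. Among the compounds with values here, no measured pair isolates this change. Compounds 1 and 3 carry the cyclobutyl amide and are far more potent than compound 2, yet they also differ from compound 2 in the core substituent and in the aromatic group, so the gain cannot be assigned to the amide alone. Within the data shown here, the step of a 1.5-fold higher number from compound 1 to compound 3 (0.18 log units; within the scatter) shows only that the aromatic group tolerates variation.

With that uncertainty, compound 4 is expected to come out near 2000 nM, within roughly 400 nM to 10000 nM, an estimated step of a 2.2-fold lower number from compound 2 to compound 4 (0.33 log units; beyond the scatter) from compound 2 toward a somewhat stronger inhibitor.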

Compound 4, half-maximal inhibitory concentration: 2 nM
Compound 4: middle estimate off by 1000-fold (3.00 log units), on the high side; the measured number lies below the stated range.
By their numbers in this assay, from the lowest: compounds 4, 1 and 3 (each within the scatter of the next, the first and the last beyond it); then compound 2.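

In this assay, within the data shown here, this is the first pair that differs only at the amide end, and putting cyclobutyl in place of 1-methylpiperidin-4-yl on the carbonyl carbon gives a 2200-fold lower number from compound 2 to compound 4 (3.33 log units; beyond the scatter). Among these compounds, this single place can therefore carry a very large change on its own, which the earlier compounds could not show, since compounds 1 and 3 differ from compound 2 in more than one place. The bromine and the fluorophenyl group also do not keep the number high by themselves, as with both still in place compound 4 gives 2 nM, but no measurement here explains why this swap has so large an effect.

The compounds shown leave open whether the size of the ring or its nitrogen matters more, a question that a cyclohexyl group, with six ring carbons and no nitrogen, or a piperidin-4-yl group without the methyl could help to separate at this carbonyl. As far as these compounds go, it also remains open whether the same swap would have an effect of similar size on a core carrying cyclopropyl instead of bromine.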